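The source may report more compounds than this note shows. Statements on the series, on what has been measured and on what is new or still open speak of the compounds shown alone.

Three compounds sharing one core have each been tested in a functional assay on HEK293 cells for agonist activity at D(4) dopamine receptor (Homo sapiens), read by FLIPR; on this read-out higher numbers stand for larger maximal responses and lower numbers for smaller maximal responses. Compound 1 `Cc1cccc(NC(=O)CN2CCC(c3ccccc3C#N)CC2)c1` gives 71% in this assay. Compound 2 `Cc1cc(C(=O)NCN2CCC(c3cccc[n+]3[O-])CC2)ccc1F` gives 67%, and compound 3 `O=C(CN1CCC(c2cccc[n+]2[O-])CC1)Nc1cccc(C(F)(F)F)c1` gives 75%. The three numbers lie within the usual scatter of one another: compound 2 is nearest to compound 1 and compound 3 is furthest from it, yet both gaps stay inside the scatter, so compound 1 sits among values that cannot be told apart on this read-out, and none of the three can be called the strongest or weakest.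

Compound 4 `COc1ccccc1C1CCN(CC(=O)Nc2cccc(C)c2)CC1` has not yet been measured. It differs from compound 1 in a single place: methoxy in place of cyano on an aromatic carbon. Going by the values given here, no measured pair isolates this exchange, since compound 2 and compound 3 each differ from compound 1 in more than one place, so nothing measured speaks to it directly. What the measured compounds do show is that several variants of the core give maximal responses within the scatter of each other. Accordingly the expected step is a number 1 percentage points lower from compound 1 to compound 4 (within the scatter), small and in neither direction beyond the scatter. Compound 4 is therefore estimated to give 70% in this assay, with an expected range from 55% to 85%.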

Compound 4, largest response reached (reported as efficacy), in percent of the reference or control that the assay uses: 43%
Compound 4: the middle estimate sits 27 percentage points above what was measured, and the stated range ends above it.
By their numbers in this assay, from the lowest: compound 4; then compounds 2, 1 and 3 (each within the scatter of the next).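

Exchanging cyano for methoxy on the aromatic carbon ortho to a large group, the change from 2-cyanophenyl to 2-methoxyphenyl, gives a number 28 percentage points lower from compound 1 to compound 4 (beyond the scatter) in this assay, so the maximal response at this receptor does depend on what stands at this position. The earlier compounds shown here could not show this, as no measured pair isolated a change at this place and their values all lay within the scatter of one another. The two groups match in heavy atom count, with one hydrogen-bond acceptor each, no hydrogen-bond donor and no net charge, so these counts do not separate them, and no measurement at hand accounts for the drop.

A single pair cannot tell whether the lower response follows from the loss of the nitrile or from the arrival of the methoxy, and a hydroxyl, an ethoxy or a chlorine atom on the same carbon would help to separate the two. Also open, as far as these compounds go, is whether the same exchange lowers the response to a similar extent when the rest of the core is changed.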